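The compounds below may be only part of what the source reports. "The series", "measured", "known", "first", "only" and "open" are said of these compounds alone.

In a functional assay for inhibition of sodium/hydrogen exchanger (Oryctolagus cuniculus) (a higher number here means a weaker inhibitor, a lower number a stronger inhibitor), compound 2 `CCOc1cc(C)c(C(=O)N=C(N)N)cc1S(C)(=O)=O` gives 19 nM, the lowest of the two numbers shown. Among the compounds with values here, its nearest neighbour is compound 1 `Cc1cc(F)c(S(C)(=O)=O)cc1C(=O)N=C(N)N`, which in this assay gives 44 nM; the step of a 2.3-fold lower number from compound 1 to compound 2 (0.36 log units; beyond the scatter) is the only measured step and concerns ethoxy in place of fluoro on an aromatic carbon. Compound 3 `Cc1cc(Oc2ccc(Cl)cc2)c(S(C)(=O)=O)cc1C(=O)N=C(N)N` has not been measured in this assay. It differs from compound 2 by 4-chlorophenyl in place of ethyl on an oxygen on an aromatic ring, or, cut one bond further out, ethoxy to 4-chlorophenoxy. Within the data shown here, the one measured step altered the same part of the shared core but exchanged a different pair of groups, so it bears only loosely on the present change, and no measured step exchanges ethyl for 4-chlorophenyl. Compound 3 is therefore expected to stay close in this assay, with an estimated step of a 1.6-fold higher number from compound 2 to compound 3 (0.20 log units; within the scatter), which is expected to lie within the scatter. The estimate for compound 3 in this assay is 30 nM, with a range from 8 nM to 120 nM.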

Compound 3, half-maximal inhibitory concentration: 13 nM
Compound 3: the middle estimate sits 2.3-fold (0.36 log units) above what was measured; measured number inside the range.
By their numbers in this assay, from the lowest: compounds 3 and 2 (each within the scatter of the next); then compound 1.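

In this assay the aromatic carbon that carries fluoro in compound 1 now also proves able to hold a far larger group: on the oxygen, 4-chlorophenyl with its 7 heavy atoms and aromatic ring replaces ethyl with its 2, and the result is a 1.5-fold lower number from compound 2 to compound 3 (0.16 log units; within the scatter) and so leaves compound 2 and compound 3 level within the scatter. Against fluoro, the 4-chlorophenoxy group gives a 3.4-fold lower number from compound 1 to compound 3 (0.53 log units; beyond the scatter) and so, like ethoxy, stands clear of the scatter, which means that both oxygen-linked groups shown have lower numbers than fluoro, while the change from a small chain to an aromatic ring on that oxygen makes no readable difference. No evidence on the origin of these numbers is at hand.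

The compounds shown leave open what the chlorine contributes, a question that a plain phenoxy group would address, and whether the oxygen link matters at all, which an anilino group on the same aromatic carbon would test. They also leave open how the number would respond to a longer chain on the oxygen, such as butyl, or to a carboxylic acid on the outer ring.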